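Swapping a halogenated ring on a shared quinolinone core

A few compounds are considered here, and "the series" means these few. Any claim that something is new, unique, unknown or untested is made for them only; others in the source may bear on it.

Measured compounds:
- compound 1, `Cc1ccc(-c2c(O)nc3cc(Cl)c([N+](=O)[O-])cc3c2OCCC2CCCCN2)c(C)c1`: 400 nM
- compound 2, `O=C(Nc1cc2c(OCCC3CCCCN3)c(-c3cccc(Br)c3)c(O)nc2cc1Cl)NC1CC1`: 6 nM
- compound 3, `Cc1cc(C)cc(-c2c(O)nc3cc(Cl)c(NC(=O)Nc4ncccn4)cc3c2OCCC2CCCCN2)c1`: 6 nM

All three were tested in a functional assay on cells (Pituitary gland cell) for antagonist activity at Gonadotropin-releasing hormone receptor (Rattus norvegicus); a higher number here means a weaker inhibitor, a lower number a stronger inhibitor. Compound 2 stands level with compound 3 at the digits given, and together these two have the lowest numbers of the set; the gap between them lies within the usual scatter. Compound 1 sits furthest away, with a number that is well beyond the scatter from compound 2. Since no single-point comparison between measured compounds is available, the data only show where each compound lies, not how much any one change is worth.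

The unmeasured compound 4, `O=C(Nc1cc2c(OCCC3CCCCN3)c(-c3ccc(Cl)c(Cl)c3)c(O)nc2cc1Cl)NC1CC1`, shares the core of compound 2 and differs in one place: 3,4-dichlorophenyl in place of 3-bromophenyl on an aromatic carbon. Both groups are halogenated phenyl rings with no hydrogen-bond donors or acceptors and no net charge, and the rest of compound 2, including the cyclopropyl urea, is kept.

Because compound 2 gives 6 nM and the change is a like-for-like halogen swap, compound 4 is expected to stay within the scatter of compound 2, a step of no change at the digits printed from compound 2 to compound 4 (within the scatter) in this assay. The estimate for compound 4 is therefore 6 nM, with a range from 2 nM to 20 nM.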

Compound 4, half-maximal inhibitory concentration: 18 nM
Compound 4: the middle estimate sits 3.0-fold (0.48 log units) below what was measured; low and high end bracket the measured number.
By their numbers in this assay, from the lowest: compounds 2 and 3 (each within the scatter of the next); then compound 4; then compound 1.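

In this assay, putting 3,4-dichlorophenyl in place of 3-bromophenyl gives a 3.0-fold higher number from compound 2 to compound 4 (0.48 log units; beyond the scatter), the first direct measure of a one-place change in this set. This position, ortho to a 2-(piperidin-2-yl)ethoxy group and ortho to a hydroxy group, therefore does not treat these two halogenated phenyl rings as interchangeable, even though the counts of hydrogen-bond donors, acceptors and charge are the same for both; the step is modest, and compound 4 still gives 18 nM. No measurement available here bears on the reason for this step.

The change swaps bromine for chlorine and also adds a second halogen, so this one pair cannot show which of the two accounts for the higher number. A 3-chlorophenyl ring, a 4-chlorophenyl ring or a plain phenyl ring at the same position, with the cyclopropyl urea kept, would help separate those contributions and show how much either halogen matters here.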